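Trimming the sulfonyl alkyl chain: compound 2 to compound 3

The source may report more compounds than this note shows. Statements on the series, on what has been measured and on what is new or still open speak of the compounds shown alone.

Within the data shown here, compound 2 `CC(C)CS(=O)(=O)N(Cc1ccc(-c2cccc(F)c2F)cc1)[C@@H](C)C(=O)N[C@H](C#N)CC(N)=O` gives 1820 nM in an assay on isolated protein for inhibition of legumain (Homo sapiens), with stated times of 2 min and 60 min (a lower number here means a stronger inhibitor, a higher number a weaker inhibitor), the lower of the two numbers measured so far. Compound 1 `C[C@H](C(=O)N[C@H](C#N)CC(N)=O)N(Cc1ccc(-c2ccc(F)c(F)c2)cc1)S(C)(=O)=O` gives 6300 nM in this assay, a number that stands beyond the scatter above that of compound 2. The two compounds differ in more than one place, so that gap is not assigned to any single change.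

Compound 3 `CCS(=O)(=O)N(Cc1ccc(-c2cccc(F)c2F)cc1)[C@@H](C)C(=O)N[C@H](C#N)CC(N)=O` has not yet been measured. It differs from compound 2 in one place only: methyl in place of isopropyl on a saturated chain carbon bound to a sulfonyl sulfur. Cut one bond further out, the change reads isobutylsulfonyl to ethylsulfonyl. Among the measured compounds shown here, no measured pair in the set shows this change on its own, so nothing here fixes its size or its direction; the series simply lacks that comparison.

The expectation for compound 3 is therefore a step of a 1.4-fold higher number from compound 2 to compound 3 (0.15 log units; within the scatter), small and plausibly within the scatter, with a lean toward a higher number. Compound 3 is estimated at 2600 nM, with a range from 1000 nM to 6500 nM.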

Compound 3, half-maximal inhibitory concentration: 1090 nM
Beside the measured number, compound 3's estimate is 2.4-fold (0.38 log units) above it; the measured number falls inside the stated range.
By their numbers in this assay, from the lowest: compounds 3 and 2 (each within the scatter of the next); then compound 1.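

Methyl in place of isopropyl on a saturated chain carbon bound to a sulfonyl sulfur, which reads as isobutylsulfonyl to ethylsulfonyl, gives in this assay a 1.7-fold lower number from compound 2 to compound 3 (0.22 log units; within the scatter), the first comparison in the series that isolates this position. Compound 2 and compound 3 therefore cannot be told apart in this read-out, and within these two compounds the isobutyl chain shows no measurable advantage over the ethyl chain on the shared core. No measured information on these compounds speaks to the reason for this result.

Compound 1 differs from compound 3 in more than one place, so the distance between them cannot be read as an effect of the sulfonyl chain alone, and the methyl end of this chain series remains without a clean comparison on the same core. Also open, as far as these compounds go, is how this assay responds at this position to a longer chain such as hexyl, or to a chain ending in an amine or a carboxylic acid.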